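This account rests on a few compounds, and the source may have more. Where it says the series, first, only, none or still open, it means among the compounds named here.

Measured so far:
compound 1, `O=C(/C=C/c1cccc(S(=O)(=O)Nc2cccc(F)c2)c1)NO`, giving 35 nM in an assay for inhibition of protein deacetylase HDAC6 (Homo sapiens), read by fluorescence, with a stated time of 3 h; on this read-out higher numbers stand for an effect only at larger amounts of compound and lower numbers for an effect already at smaller amounts
compound 2, `O=C(/C=C/c1cccc(S(=O)(=O)N2CCN(c3ccccn3)CC2)c1)NO`, giving 179 nM in this assay

Both compounds share the same core and were tested in this assay, where a lower concentration means the compound acts at smaller amounts. For the measured compounds named here, of the two numbers, compound 2 holds the higher one; its only neighbour, compound 1, sits at a lower concentration, and that gap is larger than the usual scatter of repeated measurements, so the two compounds are truly apart.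

Compound 3, `COc1ccc(N2CCN(S(=O)(=O)c3cccc(/C=C/C(=O)NO)c3)CC2)cc1`, has not yet been measured. Its structure differs from compound 2 in one place: 4-methoxyphenyl in place of pyridin-2-yl on an amine nitrogen in a ring. Going by the values given here, no pair of measured compounds differs in exactly this way, so the two values known so far give no direct guide to what this exchange does in this assay. Both groups are single aromatic rings bearing one hydrogen-bond acceptor and no donor, so the expected step from compound 2 to compound 3, a 1.2-fold lower number from compound 2 to compound 3 (0.08 log units; within the scatter), is estimated to stay within the scatter, with no clear direction. Compound 3 is therefore expected to give about 150 nM in this assay, most likely between 50 nM and 450 nM.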

Compound 3, concentration for half-maximal effect: 107 nM
The estimate for compound 3 lay 1.4-fold (0.15 log units) above the measured number, and the stated range covers the measured number.
By their numbers in this assay, from the lowest: compound 1; then compounds 3 and 2 (each within the scatter of the next).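

In this assay, putting 4-methoxyphenyl in place of pyridin-2-yl on the amine nitrogen in the ring gives a 1.7-fold lower number from compound 2 to compound 3 (0.22 log units; within the scatter), so compound 2 and compound 3 cannot be told apart. For the compounds shown here, this is the first direct reading of a change at this position, and it shows that, for this one pair, an aromatic ring of carbon only with more heavy atoms and an aromatic ring with one hetero atom give values within the usual scatter of each other. No measurement of any property of these groups is at hand that could explain this result.

As far as these compounds go, one exchange between two single aromatic rings says little about the position as a whole, so it remains open how the value would respond to a different kind of group here, such as an amine, a carboxylic acid on the aromatic ring, or a simple alkyl chain in place of the ring. Compound 1 differs from compound 2 and compound 3 in more than one place, so the gap that separates it from them cannot yet be assigned to any single part of the structure.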